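Methoxy in Place of Fluoro: An Expected Affinity Step

The source may report more compounds than this note shows. Statements on the series, on what has been measured and on what is new or still open speak of the compounds shown alone.

The measured compounds and their values:
compound 1, `Clc1cccc2c1C=C(CC1CN=CN1)CC2`, 398 nM
compound 2, `Cc1cccc2c1C=C(CC1CN=CN1)CC2`, 631 nM
compound 3, `Fc1ccc2c(c1)C=C(CC1CN=CN1)CC2`, 251 nM

All three share one core and differ only in a single substituent on the aromatic ring. In an assay on isolated protein for binding affinity to Adrenergic receptor alpha-1 (Rattus norvegicus), read by radioligand binding, in the presence of a further agent that is not named here (a higher number here means a weaker inhibitor, a lower number a stronger inhibitor), compound 3 gives 251 nM, the lowest of the three numbers. Its nearest neighbour is compound 1, which gives 398 nM, a gap within the scatter; its furthest is compound 2 at 631 nM, a gap beyond the scatter. Among the compounds with values here, the only step between measured compounds that differ in one place is a 1.6-fold higher number from compound 1 to compound 2 (0.20 log units; within the scatter), a change of one aromatic substituent for another that stayed within the scatter.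

Compound 4, `COc1ccc2c(c1)C=C(CC1CN=CN1)CC2`, arises from compound 3 by methoxy in place of fluoro on an aromatic carbon. Within the data shown here, no measured step exchanges fluoro for methoxy, so none bears on it directly; the one available step only shows that swapping one small aromatic substituent for another left this assay essentially unchanged. On that basis a step of a 1.3-fold higher number from compound 3 to compound 4 (0.11 log units; within the scatter) is expected, that is, a change that stays within the scatter. Compound 4 is therefore expected to give about 320 nM in this assay, with a range from 120 nM to 850 nM.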

Compound 4, inhibition constant: 2510 nM
For compound 4 the middle estimate is 7.8-fold (0.89 log units) below the measured one; measured number above the stated range.
By their numbers in this assay, from the lowest: compounds 3, 1 and 2 (each within the scatter of the next, the first and the last beyond it); then compound 4.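

Methoxy in place of fluoro on this aromatic carbon, meta to a fused ring and para to a fused ring, gives a 10-fold higher number from compound 3 to compound 4 (1.00 log units; beyond the scatter) in this assay and so is far from a neutral exchange. Within the data shown here, the only earlier step, a 1.6-fold higher number from compound 1 to compound 2 (0.20 log units; within the scatter) on exchanging chloro for methyl, stayed within the scatter, so the earlier compounds gave no sign that one aromatic substituent in place of another could move this assay so far. Methoxy brings 2 heavy atoms and 1 hydrogen-bond acceptor where fluoro has 1 heavy atom and none, but nothing in the data given accounts for the rise in the number.

The compounds shown leave open whether the loss follows the oxygen or the extra carbon, which hydroxy or ethyl on this same aromatic carbon could help to separate. They also leave open whether methoxy in place of chloro on the aromatic carbon that carries chloro in compound 1 would bring a step of similar size, or whether the large step belongs to this one place.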